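The source may hold more compounds than are shown below. What is called first, only, known or untested is meant among the compounds shown, and "the series" means these compounds.

In an assay on isolated protein for inhibition of Trypsin (Homo sapiens) (a lower number here means a stronger inhibitor, a higher number a weaker inhibitor), compound 1 `Cc1nn(-c2cccc(CN)c2)c2cc(-c3ccc(N4CCCCC4=O)cc3)ccc12` gives > 10000 nM, which is a limit of the assay rather than a number. Compound 2 `CN(C)Cc1nccn1-c1ccc(-c2ccc3c(C(N)=O)nn(-c4ccc5onc(N)c5c4)c3c2F)c(F)c1` gives > 10000 nM, again a limit. Compound 3 `CN(C)Cc1[nH]ncc1-c1ccc(-c2ccc3c(C(N)=O)nn(-c4ccc5onc(N)c5c4)c3c2F)c(F)c1` gives > 10000 nM, a limit as well. For the measured compounds named here, the only measured step between two compounds that differ in one place, a step that the two limits leave unreadable from compound 2 to compound 3, cannot be read: both ends sit at the same limit, which is what the limit of > 10000 nM in this assay, at which 3 of the 3 values shown sit, records. Compound 3 thus stands at the limit together with the two others and has no number of its own. Compound 4 `CN(C)Cc1ncccc1-c1ccc(-c2ccc3c(C(N)=O)nn(-c4ccc5onc(N)c5c4)c3c2F)c(F)c1` differs from compound 3 in one place: 2-((dimethylamino)methyl)pyridin-3-yl in place of 5-((dimethylamino)methyl)-1H-pyrazol-4-yl on an aromatic carbon. Going by the values given here, no measured step bears directly on this change, and the one step that comes closest gives no readable size. The expectation for compound 4 is therefore that it remains where compound 3 stands, with an expected step that the limit leaves unreadable from compound 3 to compound 4 that is no change beyond the scatter. Compound 4 is estimated at 20000 nM, within a range from 5000 nM to 100000 nM, and is expected most likely to be reported again as a limit.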

Compound 4, inhibition constant: > 10000 nM
Compound 4 was reported as a limit; the forecaster's own chance of this, stated with the estimate: 85%; the middle value is on the limit's open side.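

The steps from compound 3 to compound 4 and from compound 2 to compound 4 cannot be read, since both ends of each sit at a limit: the limit of > 10000 nM in this assay, at which 4 of the 4 values shown sit.

The compounds shown leave open how strongly any of them inhibits in this assay, and whether compound 2, compound 3 and compound 4 differ at all.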